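From hydroxy to phenyl in a growth inhibitor

A few compounds are considered here, and "the series" means these few. Any claim that something is new, unique, unknown or untested is made for them only; others in the source may bear on it.

Compound 1 `CN(C)/C=C/C(=O)c1nn(-c2ccccc2)c(-c2ccccc2)c1C#N` gives 75800 nM
Compound 2 `N#Cc1c(-c2nnc(O)c3nn(-c4ccc(Cl)cc4)cc23)nn(-c2ccccc2)c1-c1ccccc1` gives 3230 nM
Compound 3 `N#Cc1c(-c2nnc(-c3nn(-c4ccccc4)c(-c4ccccc4)c3C#N)c3nn(-c4ccc(Cl)cc4)cc23)nn(-c2ccccc2)c1-c1ccccc1` gives 61800 nM

In a functional assay on OVCAR-8 cells (Homo sapiens) for inhibition, read by sulforhodamine B assay, with a stated time of 48 h (a higher number here means a weaker inhibitor of growth, a lower number a stronger inhibitor of growth), compound 2 stands lowest of the three, and both other numbers lie beyond the scatter from it. Compound 4 `N#Cc1c(-c2nnc(-c3ccccc3)c3nn(-c4ccc(Cl)cc4)cc23)nn(-c2ccccc2)c1-c1ccccc1` has phenyl in place of hydroxy on an aromatic carbon and is otherwise the same as compound 2. Going by the values given here, no measured pair shows this change alone. At that place compound 3 (61800 nM) also lacks the hydroxy and carries a larger group. A step towards a higher number in this assay, beyond the scatter but short of that value, is therefore expected. Compound 4 is estimated at 14000 nM, within a range of 3000 nM to 60000 nM. The expected change is a 4.3-fold higher number from compound 2 to compound 4 (0.64 log units; beyond the scatter).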

Compound 4, concentration for 50% growth inhibition: 9230 nM
The estimate for compound 4 lay 1.5-fold (0.18 log units) above the measured number, and the stated range covers the measured number.
By their numbers in this assay, from the lowest: compound 2; then compound 4; then compounds 3 and 1 (each within the scatter of the next).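

In this assay, going by these compounds alone, phenyl in place of hydroxy gives a 2.9-fold higher number from compound 2 to compound 4 (0.46 log units; beyond the scatter), a modest step and the first change at this aromatic carbon that can be read alone. Growth inhibition therefore persists at a measurable level without the hydroxy, and compound 4 still gives 9230 nM with the larger, ring-bearing group. No measurement here bears on the cause of this step. On these data alone, whether the step follows from losing the hydroxy or from adding the phenyl stays open. An amine or a methoxy group at this place could help separate the two.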